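The source may report more compounds than this note shows. Statements on the series, on what has been measured and on what is new or still open speak of the compounds shown alone.

Compound 1 `CC(C)Cc1ccc(C(C)C2=NNC(S)N2N)cc1`: 30%
Compound 2 `CC(C)Cc1ccc(C(C)c2nnc(S)n2/N=C/c2ccc(Cl)cc2)cc1`: 62%

In a functional assay on the whole organism (strain Wistar albino) for inhibition, with Rattus norvegicus as the target, read by paw edema, with stated times of 30 min and 0.5 h, at a dose of 20 mg/kg by the oral route (a lower number here means less inhibition, a higher number more inhibition at the dose given (going by the name of the read-out)), compound 2 gives 62%, the highest of the two numbers shown. Its nearest neighbour is compound 1, which gives 30%, a gap beyond the usual scatter. Compound 3 `CC(C)Cc1ccc(C(C)c2nnc(S)n2/N=C/c2ccc(Br)cc2)cc1` differs from compound 2 by bromo in place of chloro on an aromatic carbon. Among the compounds with values here, no step between measured compounds shows what such an exchange does here, so the expected step from compound 2 to compound 3 is small, a number 3 percentage points higher from compound 2 to compound 3 (within the scatter), none beyond the scatter in either direction. Compound 3 is therefore expected to give about 65%, estimated to fall between 50% and 80%.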

Compound 3, a percentage reported as inhibition, in the whole organism at one dose (the size of the read-out at that dose, not a potency): 0%
Beside the measured number, compound 3's estimate is 65 percentage points above it, outside the stated range (below it).
By their numbers in this assay, from the lowest: compound 3; then compound 1; then compound 2.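

In this assay, bromo in place of chloro on an aromatic carbon gives a number 62 percentage points lower from compound 2 to compound 3 (beyond the scatter), so this position is far from indifferent to which halogen it carries. A one-atom exchange that brings no ring, no hydrogen-bond donor or acceptor and no net charge is enough to separate these two compounds. Nothing measured here accounts for this drop. The compounds shown leave open how fluoro, a methoxy group or an amine would read at this place. They also leave open whether a plain phenyl would sit nearer compound 2 or compound 3.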